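Carboxy for hydroxymethyl on a saturated ring carbon

The compounds below may be only part of what the source reports. "The series", "measured", "known", "first", "only" and "open" are said of these compounds alone.

Measured so far in an assay on Sf9 cells for inhibition of histone deacetylase 11 (Homo sapiens), read by fluorescence, tested at 0.5 uM; a lower number here means less inhibition, a higher number more inhibition at the concentration tested (going by the name of the read-out):
compound 1 `O=C(/C=C/c1cn([C@@H]2C[C@@H](CO)N(CCCc3ccccc3)C2)nn1)NO` gives 13%
compound 2 `O=C(NO)c1ccc(-c2cn([C@H]3C[C@@H](CO)N(CCCc4ccccc4)C3)nn2)cc1` gives a value at the limit, < 10%
compound 3 `O=C(/C=C/c1cn([C@@H]2C[C@@H](C(=O)O)N(CCCc3ccccc3)C2)nn1)NO` gives a value at the limit, < 10%

The limit of this assay, (the limit of < 10% in this assay, at which 2 of the 3 values shown sit), is a limit and not a number. Compound 1 and compound 2 share a hydroxamic acid head on different cores; the difference between the two cores is not broken down here. From compound 1 to compound 3 the change is carboxy in place of hydroxymethyl on a saturated ring carbon, and the step was a number at least 3 percentage points lower from compound 1 to compound 3 (that floor lies within the scatter). Compound 4 `O=C(NO)c1ccc(-c2cn([C@H]3C[C@@H](C(=O)O)N(CCCc4ccccc4)C3)nn2)cc1` has not yet been measured. From compound 2 to compound 4 the change is carboxy in place of hydroxymethyl on a saturated ring carbon, the same change made on the other core. Since compound 2 already sits at the limit, < 10%, and since compound 1 lost rather than gained inhibition on the same change, the step to compound 4 is expected to be small, a step that the limit leaves unreadable from compound 2 to compound 4. Compound 4 is estimated to give 5% in this assay, between 0% and 12%, most likely reported only as a limit.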

Compound 4, a percentage reported as inhibition, at one concentration (the size of the read-out at that concentration, not a potency): 14%
Beside the measured number, compound 4's estimate is 9 percentage points below it, and the stated range ends below it.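

In this assay, putting carboxy in place of hydroxymethyl on the saturated ring carbon gave a number at least 4 percentage points higher from compound 2 to compound 4 (that floor lies within the scatter). Set beside the same change on the core of compound 1, this result does not separate the two cores: the same change on two cores in this assay, a number at least 3 percentage points lower (that floor lies within the scatter) from compound 1 to compound 3 and a number at least 4 percentage points higher (that floor lies within the scatter) from compound 2 to compound 4; the limit leaves it open whether they differ. What it does not show is whether the change carries over in the same way from one core to the other, and the values of compound 2 and compound 3 are limits, not numbers: the limit of < 10% in this assay, at which 2 of the 4 values shown sit.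

All four compounds carry either hydroxymethyl or carboxy on this ring carbon, so the compounds shown leave open what an amine, an amide or a methyl ester would do there on either core. All four also keep the 3-phenylpropyl group, which leaves open what a shorter chain in its place would do, and whether any such change would move inhibition beyond the usual scatter.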